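Thiourea series: bromo to trifluoromethyl, compound 3 to 4

The source may hold more compounds than are shown below. What is called first, only, known or untested is meant among the compounds shown, and "the series" means these compounds.

Measured in a functional assay on HeLa cells (Homo sapiens) for antiproliferative activity, with a stated time of 24 h; on this read-out lower numbers stand for stronger inhibition and higher numbers for weaker inhibition:
Compound 1 `NC(=O)c1c(NC(=O)c2ccc(C(F)(F)F)cc2)sc2c1CCN(Cc1ccc(Cl)cc1Cl)C2` gives > 50000 nM, a limit of the assay and not a number.
Compound 2 `NC(=O)c1c(NC(=O)c2ccccc2F)sc2c1CCN(C(=S)Nc1ccccc1Cl)C2` gives 19400 nM.
Compound 3 `NC(=O)c1c(NC(=O)c2ccccc2Br)sc2c1CCN(C(=S)Nc1ccccc1Cl)C2` gives 46900 nM.

Among the compounds with values here, compound 3 stands highest of the two numbers in this assay; compound 2 is its nearest neighbour, and the single measured step, a 2.4-fold higher number from compound 2 to compound 3 (0.38 log units; beyond the scatter), is a modest shift toward weaker inhibition that lies beyond the scatter. Compound 4 `NC(=O)c1c(NC(=O)c2ccccc2C(F)(F)F)sc2c1CCN(C(=S)Nc1ccccc1Cl)C2` differs from compound 3 by trifluoromethyl in place of bromo on an aromatic carbon. Within the data shown here, no measured step exchanges bromo for trifluoromethyl at this place, so the only guide is the direction of the measured step and the fact that compound 1, which carries a trifluoromethyl elsewhere, sits at the limit of > 50000 nM in this assay, at which 1 of the 3 values shown sits. The step expected in this assay, a 1.2-fold higher number from compound 3 to compound 4 (0.07 log units; within the scatter), is therefore toward a higher number, small, and with a real chance that only a limit is returned. Compound 4 is expected to give 55000 nM, within 20000 nM to 150000 nM.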

Compound 4, half-maximal inhibitory concentration: 46900 nM
Beside the measured number, compound 4's estimate is 1.2-fold (0.07 log units) above it; low and high end bracket the measured number.
By their numbers in this assay, from the lowest: compound 2; then compounds 3 and 4 (each within the scatter of the next). At a limit, above all of these: compound 1.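

Trifluoromethyl in place of bromo on this aromatic carbon, ortho to a large group, gives no change at the digits printed from compound 3 to compound 4 (within the scatter) in this assay, so exchanging 1 heavy atom for 4 leaves the read-out unmoved. Trifluoromethyl in place of fluoro gives a 2.4-fold higher number from compound 2 to compound 4 (0.38 log units; beyond the scatter), matching the earlier fluoro to bromo step of a 2.4-fold higher number from compound 2 to compound 3 (0.38 log units; beyond the scatter), so among these three groups fluoro alone stands apart, while bromo and trifluoromethyl cannot be told apart. Little room for any weaker result remains in this read-out: the limit of > 50000 nM in this assay, at which 1 of the 4 values shown sits.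

Going by these compounds, whether an amine, a methoxy or a carboxylic acid at this place would give a lower number than compound 2 stays open. Also open, on these data alone, is whether the flat bromo to trifluoromethyl result holds with a group other than 2-chlorophenyl on the thiourea.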